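Extending the Ether on a Shared Core

The source may hold more compounds than are shown below. What is called first, only, known or untested is meant among the compounds shown, and "the series" means these compounds.

Measured compounds:
compound 1, `COc1ccc2c(c1)SCC(=O)N2`, 21100 nM
compound 2, `O=C1CSc2cc(OCc3ccc(Br)cc3)ccc2N1`, 15600 nM
compound 3, `O=C1CSc2cc(OCCc3ccccc3)ccc2N1`, 13100 nM

Of the compounds shown here, three on the core of compound 1 have been tested in an assay on isolated protein for inhibition of Amine oxidase [flavin-containing] A (Homo sapiens), read by fluorescence and spectrophotometry, with a stated time of 20 min; a higher number here means a weaker inhibitor, a lower number a stronger inhibitor. Compound 1 gives the highest of the three numbers, yet its gaps to compound 2 and to compound 3 both fall within the scatter, so none of the three can be set apart from the others. Compound 4 `O=C1CSc2cc(OCC3CCCCC3)ccc2N1` carries cyclohexyl in place of hydrogen on a saturated chain carbon bound to an oxygen on an aromatic ring. For the measured compounds named here, no pair of measured compounds isolates this change. Compound 2 and compound 3 sit within the scatter of compound 1, so only a small step, if anything toward a lower number, is expected: a 1.8-fold lower number from compound 1 to compound 4 (0.25 log units; within the scatter). Compound 4 is estimated at 12000 nM, with a range from 4000 nM to 40000 nM.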

Compound 4, half-maximal inhibitory concentration: 1170 nM
Compound 4: middle estimate off by 10-fold (1.01 log units), on the high side; the measured number lies below the stated range.
By their numbers in this assay, from the lowest: compound 4; then compounds 3, 2 and 1 (each within the scatter of the next).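

In this assay, cyclohexyl in place of hydrogen on a saturated chain carbon bound to an oxygen on an aromatic ring gives an 18-fold lower number from compound 1 to compound 4 (1.26 log units; beyond the scatter) and this step lies beyond the scatter. For the compounds shown here, compounds 1, 2 and 3 could not be set apart, so this is the first sign that a change at this position can move the number on the shared core. Nothing given here bears on why this change has so large an effect.

The compounds shown leave open whether the cyclohexyl ring itself is needed, or whether an open hexyl chain would serve as well. They also leave open how an amine on that ring would read.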